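Shifting the Fluorine on the Benzyl Group

This account rests on a few compounds, and the source may have more. Where it says the series, first, only, none or still open, it means among the compounds named here.

Compound 1 `N#Cc1cccc(COc2ccc(-c3cc(CN4CCN(c5ccc(C(F)(F)F)cc5)CC4)no3)cc2)c1`: 2000 nM
Compound 2 `N#Cc1cccc(COc2ccc(-c3cc(CN4CCN(c5ccc(F)cc5)CC4)no3)cc2)c1`: 2400 nM
Compound 3 `N#Cc1cccc(COc2ccc(-c3cc(CN4CCN(Cc5ccc(F)cc5)CC4)no3)cc2)c1`: 1800 nM

In a functional assay on MCF7 cells (Homo sapiens) for antiproliferative activity, read by sulforhodamine B assay, with a stated time of 72 h (on this read-out lower numbers stand for stronger inhibition and higher numbers for weaker inhibition), compound 3 gives 1800 nM, the lowest of the three numbers, though its gaps to the others stay within the scatter: a 1.1-fold lower number from compound 1 to compound 3 (0.05 log units; within the scatter) and a 1.3-fold lower number from compound 2 to compound 3 (0.12 log units; within the scatter). Compound 4 `N#Cc1cccc(COc2ccc(-c3cc(CN4CCN(Cc5cccc(F)c5)CC4)no3)cc2)c1` differs from compound 3 by 3-fluorophenyl in place of 4-fluorophenyl on a saturated chain carbon bound to an amine nitrogen in a ring. Among the measured compounds shown here, none of the measured steps moves a fluorine from one position of the ring to another; the steps in hand, a 1.2-fold higher number from compound 1 to compound 2 (0.08 log units; within the scatter) and a 1.3-fold lower number from compound 2 to compound 3 (0.12 log units; within the scatter), both alter the group on the amine nitrogen in a ring and both stay within the scatter. Compound 4 is therefore expected to show no step beyond the scatter, a 1.1-fold higher number from compound 3 to compound 4 (0.02 log units; within the scatter). Compound 4 is estimated at 1900 nM, between 900 nM and 4000 nM.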

Compound 4, half-maximal inhibitory concentration: 2400 nM
The estimate for compound 4 lay 1.3-fold (0.10 log units) below the measured number, and the stated range covers the measured number.
By their numbers in this assay, from the lowest: compounds 3, 1, 2 and 4 (each within the scatter of the next).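

Moving the fluorine, 3-fluorobenzyl in place of 4-fluorobenzyl, gives the first direct reading of ring position at this place: a 1.3-fold higher number from compound 3 to compound 4 (0.12 log units; within the scatter) in this assay, so no effect of the shift can be read. The comparisons with the earlier groups on the amine nitrogen in a ring, no change at the digits printed from compound 2 to compound 4 (within the scatter) and a 1.2-fold higher number from compound 1 to compound 4 (0.08 log units; within the scatter), likewise show no separation. Nothing available explains this flat result. Still open, as far as these compounds go, is whether a methoxy group, a carboxylic acid or an amine on this benzyl ring, or a longer chain in place of the benzyl carbon, would move the number beyond the scatter.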